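Ethyl Ester in Place of the Free Acid

The source may report more compounds than this note shows. Statements on the series, on what has been measured and on what is new or still open speak of the compounds shown alone.

Compound 3 `O=C(O)/C=C/c1cn(-c2ccc(O)cc2)nc1-c1ccccc1` has no number in a functional assay (Mus musculus) for inhibition, with a stated time of 5 days; a lower number here means a stronger inhibitor, a higher number a weaker inhibitor. Compound 3 gives only a limit, > 100000 nM.

Compound 4 `CCOC(=O)/C=C/c1cn(-c2ccc(O)cc2)nc1-c1ccccc1` differs from it in one place: ethyl in place of hydrogen on an oxygen next to a carbonyl group, with ethyl in place of hydrogen on an oxygen next to a carbonyl group, which reads as carboxy to ethoxycarbonyl.

For the measured compounds named here, no measured step makes this same change. The nearest evidence comes from compound 1 `CCOC(=O)/C=C/c1cn(-c2ccc(O)cc2)nc1-c1ccc(O)c(O)c1` and compound 2 `CCOC(=O)/C=C/c1cn(-c2ccc(O)cc2)nc1-c1ccc(O)cc1`, which both carry the 2-(ethoxycarbonyl)ethenyl group found in compound 4. In this assay compound 1 gives 6200 nM and compound 2 gives 25000 nM. Between them lies a different change, hydrogen in place of hydroxy on an aromatic carbon, which amounts to a 4.0-fold higher number from compound 1 to compound 2 (0.61 log units; beyond the scatter).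

Both of these esters give numbers, whereas the acid gives only a limit, so a move towards a lower number is expected. The weaker ester value of compound 2, 25000 nM, suggests that this move will stay modest. The expected change is an at least 2.2-fold lower number from compound 3 to compound 4 (0.34 log units; beyond the scatter).

For compound 4 the estimated value is 45000 nM, with an expected range of 15000 nM to 100000 nM.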

Compound 4, half-maximal inhibitory concentration: 29000 nM
For compound 4 the middle estimate is 1.6-fold (0.19 log units) above the measured one; the range from low to high includes it.
By their numbers in this assay, from the lowest: compound 1; then compounds 2 and 4 (each within the scatter of the next). At a limit, above all of these: compound 3.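

In this assay, replacing the carboxy group with ethoxycarbonyl gives an at least 3.4-fold lower number from compound 3 to compound 4 (0.53 log units; beyond the scatter), the first direct reading of this change, and that size is only a lower bound because compound 3 stands at a limit: the limit of > 100000 nM in this assay, at which 1 of the 4 values shown sits.

With the ethoxycarbonyl group kept, the second hydroxy removal gives a 1.2-fold higher number from compound 2 to compound 4 (0.06 log units; within the scatter), which lies within the scatter. Replacing the whole 3,4-dihydroxyphenyl group with phenyl gives a 4.7-fold higher number from compound 1 to compound 4 (0.67 log units; beyond the scatter), so the measurable loss appears at the first hydroxy removal, a 4.0-fold higher number from compound 1 to compound 2 (0.61 log units; beyond the scatter), and not at the second.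

From the compounds shown here alone, how far the acid lies beyond its limit remains open, and with it the full size of the ester step. Also open, going by these compounds, is whether a methyl ester, a longer chain on the oxygen or an amide in place of the ester would give a similar number.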